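The compounds below may be only part of what the source reports. "The series", "measured", "known", "first", "only" and "open" are said of these compounds alone.

Among the measured compounds shown here, compound 3 `O=C(NC1CC1)c1cccc(S(=O)(=O)Oc2ccc(-c3cncn3C3CCN(C(=O)c4ccc([N+](=O)[O-])cc4)CC3)cc2)c1` gives 152 nM in an assay on HEK293 cells for antagonist activity at P2X purinoceptor 7 (Homo sapiens), read by fluorescence, with a stated time of 2 h (on this read-out higher numbers stand for weaker inhibition and lower numbers for stronger inhibition), the second highest of the three numbers known. Compound 1 `O=C(NC1CC1)c1cccc(S(=O)(=O)Oc2ccc(-c3cncn3C3CCN(C(=O)c4ccc(Cl)c(C(F)(F)F)c4)CC3)cc2)c1` gives 88 nM in this assay and lies within the scatter of compound 3, while compound 2 `CS(=O)(=O)c1ccc(C(=O)N2CCC(n3cncc3-c3ccc(OS(=O)(=O)c4cccc(C(=O)NC5CC5)c4)cc3)CC2)cc1` gives 400 nM in this assay, beyond it. Compound 4 `CN(C)c1ccc(C(=O)N2CCC(n3cncc3-c3ccc(OS(=O)(=O)c4cccc(C(=O)NC5CC5)c4)cc3)CC2)cc1` differs from compound 3 by dimethylamino in place of nitro on an aromatic carbon. For the measured compounds named here, the steps that bear on this exchange are the earlier swaps of the group on that aromatic carbon: a 2.6-fold lower number from compound 2 to compound 3 (0.42 log units; beyond the scatter), a 1.7-fold higher number from compound 1 to compound 3 (0.24 log units; within the scatter) and a 4.5-fold higher number from compound 1 to compound 2 (0.66 log units; beyond the scatter), all modest or within the scatter. Going by the values given here, no measured compound carries dimethylamino, so the direction is open; at most a modest step is expected in this assay. Compound 4 is therefore estimated at 250 nM in this assay, with a range of 80 nM to 800 nM, which means an expected 1.6-fold higher number from compound 3 to compound 4 (0.22 log units; within the scatter).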

Compound 4, half-maximal inhibitory concentration: 0.49 nM
For compound 4 the middle estimate is 510-fold (2.71 log units) above the measured one, outside the stated range (below it).
By their numbers in this assay, from the lowest: compound 4; then compounds 1 and 3 (each within the scatter of the next); then compound 2.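

Dimethylamino on this aromatic carbon, para to a large group, sets compound 4 apart from the others in this assay: a 310-fold lower number from compound 3 to compound 4 (2.49 log units; beyond the scatter), an 820-fold lower number from compound 2 to compound 4 (2.91 log units; beyond the scatter) and a 180-fold lower number from compound 1 to compound 4 (2.25 log units; beyond the scatter). Each of these steps is large, whereas nitro, methylsulfonyl and the 4-chloro-3-(trifluoromethyl)phenyl variant differ only modestly or within the scatter, so this position can carry far more effect than those swaps showed. No measurement shown accounts for the gain.

As far as these compounds go, whether it is specific to dimethylamino stays open. Amino, methylamino, pyrrolidine or methoxy at this place would test that.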